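Swapping the benzothiazole for a benzimidazole on the ester arm

The compounds below may be only part of what the source reports. "The series", "measured", "known", "first", "only" and "open" are said of these compounds alone.

Of the compounds shown here, three sharing one core have been measured in a functional assay on A549 cells (Homo sapiens) for cytotoxicity, read by MTT assay, with a stated time of 72 h; a higher number here means a weaker inhibitor, a lower number a stronger inhibitor. Compound 1 `C=C1C2=C(C(=O)N1OC)[C@H](OC(=O)CSc1nc3ccccc3s1)[C@@](C)(O)[C@H](CCCCC)O2` gives 5900 nM and stands at the lowest of the three numbers, which here means the strongest inhibitor. Compound 2 `C=C1C2=C(C(=O)N1OC)[C@H](O)[C@@](C)(O)[C@H](CCCCC)O2` carries a free hydroxyl where compound 1 carries an ester; in this assay compound 2 gives 41000 nM. Compound 3 `C=C1C2=C(C(=O)N1OC)[C@H](OC(=O)CCCCCl)[C@@](C)(O)[C@H](CCCCC)O2`, with a 4-chlorobutyl chain on the ester, gives 12000 nM. The two measured steps concern this ester arm: a 3.4-fold lower number from compound 2 to compound 3 (0.53 log units; beyond the scatter), and a 2.0-fold higher number from compound 1 to compound 3 (0.31 log units; beyond the scatter). Both show that what hangs on the ester changes the number only modestly.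

Compound 4 `C=C1C2=C(C(=O)N1OC)[C@H](OC(=O)CSc1nc3ccccc3[nH]1)[C@@](C)(O)[C@H](CCCCC)O2` has not yet been measured. It differs from compound 1 in one place: 1H-benzimidazol-2-yl in place of 1,3-benzothiazol-2-yl on a sulfur. Within the data shown here, no measured step touches this particular swap, so the expectation rests only on how gently the ester arm has shifted the numbers so far. A step no larger than those measured ones is expected, most likely staying close to compound 1 or drifting slightly toward a higher number, as a 1.3-fold higher number from compound 1 to compound 4 (0.10 log units; within the scatter). Compound 4 is therefore estimated at 7500 nM in this assay, within a range from 3000 nM to 20000 nM.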

Compound 4, half-maximal inhibitory concentration: 19000 nM
Compound 4: middle estimate off by 2.5-fold (0.40 log units), on the low side, and the stated range covers the measured number.
By their numbers in this assay, from the lowest: compound 1; then compounds 3 and 4 (each within the scatter of the next); then compound 2.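

Inside the ester arm, the ring on the sulfur matters: exchanging only the ring sulfur of the 1,3-benzothiazol-2-yl group for the nitrogen and hydrogen of 1H-benzimidazol-2-yl gives a 3.2-fold higher number from compound 1 to compound 4 (0.51 log units; beyond the scatter) in this assay. Among these compounds, this small edit, which keeps the heavy-atom count and the link through sulfur, moves the number about as far as adding the whole ester arm does in a 3.4-fold lower number from compound 2 to compound 3 (0.53 log units; beyond the scatter), so the earlier steps did not show how sensitive the arm is to a single ring atom. A fused aromatic ring on the sulfur also brings no edge by itself, since a 1.6-fold higher number from compound 3 to compound 4 (0.20 log units; within the scatter) leaves the benzimidazole arm and the 4-chlorobutyl ester arm unseparated.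

Nothing at hand explains why the two rings differ in this assay. As far as these compounds go, a 1-methylbenzimidazol-2-yl or 1,3-benzoxazol-2-yl group on the same sulfur would test whether the number follows the amide-like ring hydrogen or the ring sulfur, and that question remains open.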